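The source may hold more compounds than are shown below. What is called first, only, known or untested is meant among the compounds shown, and "the series" means these compounds.

In a functional assay on the whole organism for inhibition, with Mus musculus as the target, with a stated time of 3 h, at a dose of 50 mg/kg by the oral route (on this read-out higher numbers stand for more inhibition at the one dose given (going by the name of the read-out) and lower numbers for less inhibition), three compounds have been measured. Compound 2 `O=S(=O)(c1ccccc1)c1cnc2ncnn2c1-c1ccc(Br)cc1` gives 1.6%, and compound 1 `Cc1ccc(-c2c(S(=O)(=O)c3ccccc3)cnc3ncnn23)cc1` gives 4.4%. These two share one core and differ by one group: methyl in place of bromo on an aromatic carbon. The step they make is a number 2.8 percentage points higher from compound 2 to compound 1 (within the scatter), so the two read-outs show no difference that can be relied on. Compound 3 `Cc1ccc(-c2c(S(=O)(=O)c3ccccc3)cnc3cc(-c4ccc(Br)cc4)nn23)cc1` gives 69.2%, the highest of the three, beyond the scatter from both compound 1 and compound 2. How the core of compound 3 differs from the core of compound 2 is not broken down here.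

Compound 4 `Cc1ccc(-c2cc3ncc(S(=O)(=O)c4ccccc4)c(-c4ccc(C)cc4)n3n2)cc1` has not yet been measured in this assay. It is reached from compound 3 by the same change that leads from compound 2 to compound 1: methyl in place of bromo on an aromatic carbon. Because that change made the step of a number 2.8 percentage points higher from compound 2 to compound 1 (within the scatter) on the other core, compound 4 is expected to stay close to compound 3, with an estimated step of a number 4.2 percentage points lower from compound 3 to compound 4 (within the scatter). Compound 4 is therefore estimated at 65%, most likely between 45% and 85%.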

Compound 4, a percentage reported as inhibition, in the whole organism at one dose (the size of the read-out at that dose, not a potency): 31.2%
Compound 4: the middle estimate sits 33.8 percentage points above what was measured; measured number outside the range, below it.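

In this assay, the change from 4-bromophenyl to 4-methylphenyl on the second core gives a number 38 percentage points lower from compound 3 to compound 4 (beyond the scatter), whereas on the first core it gives a number 2.8 percentage points higher from compound 2 to compound 1 (within the scatter). For the compounds shown here, the effect of this change therefore did not carry from one core to the other: the same change on two cores in this assay, a number 2.8 percentage points higher (within the scatter) from compound 2 to compound 1 and a number 38 percentage points lower (beyond the scatter) from compound 3 to compound 4, 40.8 percentage points apart, beyond the scatter of two such steps This shows that, in these four compounds, the size of the step depends on which pair is read, but with only one pair per core and a single oral dose, it does not show why the two steps differ, nor what the change would do on any further core.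

The compounds shown leave open whether the higher reading of compound 3 needs bromo itself or would also hold with chloro, fluoro or methoxy in its place. They also leave open how an amine or a carboxylic acid would read there, and whether replacing the phenylsulfonyl group would alter the picture on either core.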